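This account rests on a few compounds, and the source may have more. Where it says the series, first, only, none or still open, it means among the compounds named here.

Working notes on the series. In an ADME assay on microsomes from liver (Homo sapiens) for metabolic stability, with a stated time of 10 min (on this read-out higher numbers stand for a more stable compound and lower numbers for a less stable compound), compound 3 `Cc1c(Cl)cccc1Oc1cccn2c(C3CCC(C)(O)CC3)nnc12` gives 99%, the highest of the three values; compound 1 `Cc1c(Cl)cccc1Oc1cccn2c(C34CCC(CC3)C4)nnc12` gives 69% and compound 2 `Cc1c(Cl)cccc1Oc1cccn2c([C@]34CCC(C[C@H]3O)C4(C)C)nnc12` gives 25%. Among the compounds with values here, the one measured step on the same aromatic carbon, a number 30 percentage points higher from compound 1 to compound 3 (beyond the scatter), does not involve either of the groups now exchanged. Compound 4 `CC(=O)N1CCC(c2nnc3c(Oc4cccc(Cl)c4C)cccn23)CC1` carries 1-acetylpiperidin-4-yl in place of 4-hydroxy-4-methylcyclohexyl on an aromatic carbon. Within the data shown here, no measured step covers this exchange, so the direction of the step rests on the starting point alone: compound 3 sits near the top of the read-out, and a somewhat lower number is expected for compound 4, with the size uncertain. The expected step is a number 19 percentage points lower from compound 3 to compound 4 (beyond the scatter). For compound 4 in this assay the estimate is 80%, within 55% to 99%.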

Compound 4, percent of the compound remaining: 87%
Compound 4: the middle estimate sits 7 percentage points below what was measured; low and high end bracket the measured number.
By their numbers in this assay, from the lowest: compound 2; then compound 1; then compound 4; then compound 3.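

At this aromatic carbon, a six-membered non-aromatic ring with 1 hetero atom and 0 hydrogen-bond donors keeps the number high: in this assay, 1-acetylpiperidin-4-yl in place of 4-hydroxy-4-methylcyclohexyl gives a number 12 percentage points lower from compound 3 to compound 4 (beyond the scatter) in this series. The same group gives a number 18 percentage points higher from compound 1 to compound 4 (beyond the scatter), so both six-membered rings stand above the two five-membered rings of compound 1. No measurement here bears on the reason for either step. From the compounds shown here alone, compound 4 changes the ring atom and adds the acetyl group together, so their separate shares remain open. A free piperidine amine or a carboxylic acid at this place would be needed to separate them.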